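This account rests on a few compounds, and the source may have more. Where it says the series, first, only, none or still open, it means among the compounds named here.

In an ADME assay on cells (Hepatocyte, Homo sapiens) for metabolic stability, read by LC-MS, tested at 1 uM (on this read-out higher numbers stand for a more stable compound and lower numbers for a less stable compound), compound 1 (`Cc1ccnc(NC(=O)c2ccsc2NC(=O)c2ccc(S(=O)(=O)N3CCCCC3)cc2)n1`) gives 41.2% and compound 2 (`CCOC(=O)NC(=O)c1ccsc1NC(=O)c1ccc(S(=O)(=O)N2CCCC2)cc1`) gives 42% on the same read-out, so compound 2 stands level with compound 1 within the scatter. Compound 3 (`CCOC(=O)NC(=O)c1ccsc1NC(=O)c1ccc(S(=O)(=O)N2CCCCC2)cc1`) carries piperidin-1-yl in place of pyrrolidin-1-yl on a sulfonyl sulfur of compound 2 (piperidin-1-yl in place of pyrrolidin-1-yl on a sulfonyl sulfur). For the measured compounds named here, no measured pair shows this change alone. Compound 1 also carries piperidin-1-yl on a sulfonyl sulfur and gives 41.2% at the level of compound 2, so no step beyond the scatter is expected in either direction. The estimated step of a number 2 percentage points lower from compound 2 to compound 3 (within the scatter) stays within that scatter. In this assay compound 3 is expected at 40% with 25% to 55% as its estimated range.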

Compound 3, percent of the compound remaining: 49.8%
Compound 3: the middle estimate sits 9.8 percentage points below what was measured, and the stated range covers the measured number.
By their numbers in this assay, from the lowest: compounds 1, 2 and 3 (each within the scatter of the next).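

In this assay, for the compounds shown here, the pair compound 2 and compound 3 isolates piperidin-1-yl in place of pyrrolidin-1-yl on a sulfonyl sulfur for the first time, giving a number 7.8 percentage points higher from compound 2 to compound 3 (within the scatter). Ethoxycarbonyl in place of 4-methylpyrimidin-2-yl on an amide-type nitrogen gives a number 8.6 percentage points higher from compound 1 to compound 3 (within the scatter), so neither change moves the read-out beyond the scatter. Nothing available explains either step. Still open, as far as these compounds go, is whether morpholin-4-yl or an open-chain dimethylamino group on the sulfonyl sulfur would give a step beyond the scatter. The same question applies to a carboxylic acid in place of ethoxycarbonyl on the amide-type nitrogen.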